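Notes on compound 4 in the shared series

The compounds below may be only part of what the source reports. "The series", "measured", "known", "first", "only" and "open" are said of these compounds alone.

Values in an assay on COS-7 cells for inhibition of tyrosine-protein kinase receptor TYRO3 (Homo sapiens), read by ELISA, with a stated time of 1 h; a lower number here means a stronger inhibitor, a higher number a weaker inhibitor:
compound 1 `Cc1cc(-c2c(C)nn(C)c2C)ccc1-c1nnc(N(C)Cc2ccc3nccn3c2)o1`: > 31600 nM
compound 2 `Cc1cc(-c2c(C)nn(C)c2C)ccc1-c1nnc(N(C)Cc2ccc3ncc(-c4ccccc4)n3c2)o1`: 20000 nM
compound 3 `Cc1cc(-c2c(C)nn(C)c2C)ccc1-c1nnc(N(C)Cc2ccc3ncc(C4CCN(C)CC4)n3c2)o1`: > 31600 nM

For compound 3 the value is a limit of this assay, not a number. For compound 1 the value is likewise a limit. Both therefore stand at the limit of > 31600 nM in this assay, at which 2 of the 3 values shown sit, and only compound 2 gives a readable number. The step that the two limits leave unreadable from compound 1 to compound 3 cannot be read; the steps of an at least 1.5-fold lower number from compound 1 to compound 2 (0.19 log units; that floor lies within the scatter) and an at least 1.5-fold higher number from compound 2 to compound 3 (0.19 log units; that floor lies within the scatter) are each a floor that lies within the scatter, so no ordering of the three compounds is secure.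

Compound 4 `Cc1cc(-c2c(C)nn(C)c2C)ccc1-c1nnc(N(C)Cc2ccc3ncc(-c4cnn(CCN(C)C)c4)n3c2)o1` differs from compound 3 by 1-(2-(dimethylamino)ethyl)-1H-pyrazol-4-yl in place of 1-methylpiperidin-4-yl on an aromatic carbon. Going by the values given here, the one measured step that bears on this change is an at least 1.5-fold higher number from compound 2 to compound 3 (0.19 log units; that floor lies within the scatter), in which the aromatic phenyl gave the only number and the saturated 1-methylpiperidin-4-yl gave the limit. Compound 4 returns an aromatic ring to that carbon, now carrying a 1-(2-(dimethylamino)ethyl) chain. Compound 4 is therefore expected to move back toward the level of compound 2, a downward step an at least 1.5-fold lower number from compound 3 to compound 4 (0.19 log units; that floor lies within the scatter) in this assay, though a limit is also plausible since that floor sits within the scatter. Compound 4 is estimated at 20000 nM, with a range from 7000 nM to 40000 nM.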

Compound 4, half-maximal inhibitory concentration: 12600 nM
Estimate against measurement, compound 4: 1.6-fold (0.20 log units) above, within the range that was stated.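

In this assay, going by these compounds alone, this carbon of the five-membered aromatic ring now has a second substituent that gives a readable number, and the series gains an at least 2.5-fold lower number from compound 3 to compound 4 (0.39 log units; beyond the scatter) and an at least 2.5-fold lower number from compound 1 to compound 4 (0.39 log units; beyond the scatter), the first steps here that clear the scatter. Set against the phenyl of compound 2, the new group gives a 1.6-fold lower number from compound 2 to compound 4 (0.20 log units; within the scatter), so 1-(2-(dimethylamino)ethyl)-1H-pyrazol-4-yl and phenyl cannot be told apart at this position. Among the four compounds, the two with an aromatic ring on this carbon give numbers, while hydrogen in compound 1 and 1-methylpiperidin-4-yl in compound 3 remain at a limit of the assay: the limit of > 31600 nM in this assay, at which 2 of the 4 values shown sit.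

The compounds shown do not separate the pyrazole ring from its dimethylaminoethyl chain; a 1-methyl-1H-pyrazol-4-yl group, or a pyrazole carrying a longer chain ending in a morpholine or a carboxylic acid, would bear on that question. On these data alone, the step between compound 1 and compound 3 cannot be read, and the position of either compound beyond its limit remains unknown.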